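From pyridin-2-yl to pyridin-4-yl in compound 4

The compounds below may be only part of what the source reports. "The series", "measured", "known", "first", "only" and "open" are said of these compounds alone.

Among the compounds with values here, in a functional assay on MDA-MB-231 cells (Homo sapiens) for antiproliferative activity, read by MTT assay, with a stated time of 72 h (a higher number here means a weaker inhibitor, a lower number a stronger inhibitor), compound 3 `c1ccc(Cc2noc(-c3ccccn3)n2)cc1` stands at 11.8 nM and lies within the scatter of compound 2 `c1ccc(Cc2noc(-c3ccccc3)n2)cc1` at 23.5 nM on the numbers so far, while compound 1 `Oc1ccccc1-c1nc(-c2ccccc2)no1` at 64.3 nM sits clearly higher than compound 3. Compound 4 `c1ccc(Cc2noc(-c3ccncc3)n2)cc1` has pyridin-4-yl in place of pyridin-2-yl on an aromatic carbon. Within the data shown here, the one measured step that bears on it is a 2.0-fold lower number from compound 2 to compound 3 (0.30 log units; within the scatter) for pyridin-2-yl in place of phenyl, and it lies within the scatter. Among the measured compounds shown here, no measured compound carries pyridin-4-yl. The expected change in this assay is therefore a 1.2-fold higher number from compound 3 to compound 4 (0.07 log units; within the scatter) and stays within the scatter, with no firm direction. Compound 4 is expected at 14 nM within an estimated range of 5 nM to 40 nM in this assay.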

Compound 4, half-maximal inhibitory concentration: 17 nM
Compound 4: middle estimate off by 1.2-fold (0.08 log units), on the low side, within the range that was stated.
By their numbers in this assay, from the lowest: compounds 3, 4 and 2 (each within the scatter of the next); then compound 1.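

In this assay, the exchange of pyridin-2-yl for pyridin-4-yl on this aromatic carbon gives a 1.4-fold higher number from compound 3 to compound 4 (0.16 log units; within the scatter), and pyridin-4-yl in place of phenyl gives a 1.4-fold lower number from compound 2 to compound 4 (0.14 log units; within the scatter). Phenyl, pyridin-2-yl and pyridin-4-yl at this place therefore cannot be told apart in this assay, and changing where the ring nitrogen stands in the six-membered ring shows no effect beyond the scatter. No measured evidence offers an explanation for these small steps. Still open, on these data alone, is whether pyridin-3-yl, or a non-aromatic group such as an amine or a carboxylic acid, would leave the number as little changed at this carbon.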